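The source may hold more compounds than are shown below. What is called first, only, known or untested is meant among the compounds shown, and "the series" means these compounds.

Measured compounds:
- compound 1, `COc1cccc(/C=C/c2cc3c(c(=O)n(C)c(=O)n3C)n2C)c1`, 370 nM
- compound 2, `Cn1c(=O)c2c(cc(/C=C/c3ccc(C(F)(F)F)cc3)n2C)n(C)c1=O`, 432 nM

Both compounds were tested in an assay on isolated protein for inhibition of Amine oxidase [flavin-containing] B (Homo sapiens), read by luminescence, with a stated time of 1 h; a lower number here means a stronger inhibitor, a higher number a weaker inhibitor. Compound 2 has the higher of the two numbers, but its gap to compound 1 is within the scatter of repeated measurements, so nothing separates the two beyond the usual noise; compound 1 and compound 2 simply read alike in this assay.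

Compound 3, `Cn1c(=O)c2c(cc(/C=C/c3ccc(S(C)(=O)=O)cc3)n2C)n(C)c1=O`, has not yet been measured. It differs from compound 2 in one place: methylsulfonyl in place of trifluoromethyl on an aromatic carbon. For the measured compounds named here, no pair of measured compounds shows this exchange, so there is no measured step to lean on, and the only anchors are the values of compound 1 and compound 2, which sit close together.

Given that, compound 3 is expected to land near compound 2, with a modest step in this assay toward a higher number being the more likely outcome; the estimated step is a 1.7-fold higher number from compound 2 to compound 3 (0.24 log units; within the scatter). The estimate for compound 3 in this assay is 750 nM, within a range from 200 nM to 2800 nM.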

Compound 3, half-maximal inhibitory concentration: > 1000 nM
Compound 3: only a limit was reported; the forecaster's own chance of this, stated with the estimate: 5%; at least 1.3-fold (0.12 log units) between middle value and limit.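

In this assay compound 3 gives > 1000 nM, which is a limit of the assay and not a number. For the compounds shown here, the position on an aromatic carbon, para to a large group, is therefore not indifferent to what sits on it: methylsulfonyl in place of trifluoromethyl gives an at least 2.3-fold higher number from compound 2 to compound 3 (0.36 log units; beyond the scatter), the first single-place change and one that lies beyond the scatter. Both groups have 4 heavy atoms, so this exchange keeps that count while adding 2 hydrogen-bond acceptors, and the size of the step is only a minimum since the reading stops at a limit: the limit of > 1000 nM in this assay, at which 1 of the 3 values shown sits.

The compounds shown leave open how far compound 3 really lies from compound 2, and whether the loss follows from the hydrogen-bond acceptors or from something else about methylsulfonyl. They also leave open how a nitrile, an amine or a carboxylic acid on this same carbon would read in this assay, and whether the same exchange would give a similar step on another carbon of this ring.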